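The compounds below may be only part of what the source reports. "The series", "measured", "known", "first", "only" and "open" are said of these compounds alone.

Of the compounds shown here, three built on one shared core have been measured. Compound 1 `COc1cc(/C=C/C(=O)c2cc(-c3cc(OC)c(OC)c(OC)c3)n3nc(-c4ccccc4)cc3n2)cc(OC)c1OC` gives 17900 nM in a functional assay on DU-145 cells (Homo sapiens) for antiproliferative activity, read by MTT assay, with a stated time of 24 h; a higher number here means a weaker inhibitor, a lower number a stronger inhibitor. Compound 2 `COc1ccc(-c2cc(C(=O)/C=C/c3cc(OC)c(OC)c(OC)c3)nc3cc(-c4ccccc4)nn23)cc1OC` gives 14700 nM in this assay, and compound 3 `COc1cc(-c2cc(/C=C/C(=O)c3ccc(C)c(C)c3)nc3cc(-c4ccccc4)nn23)cc(OC)c1OC` gives 15400 nM in this assay. Compound 2 has the lowest of the three numbers, but all three sit within the usual scatter of one another, so no order among them can be read off.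

Compound 4 `COc1ccc(/C=C/C(=O)c2cc(-c3ccc(OC)c(OC)c3)n3nc(-c4ccccc4)cc3n2)cc1` has not yet been measured. It differs from compound 2 in one place: 4-methoxyphenyl in place of 3,4,5-trimethoxyphenyl on a double-bonded chain carbon bound to a double-bonded chain carbon. For the measured compounds named here, the only measured step that bears on a change of this kind is the one from compound 1 to compound 2, where a single methoxy on an aromatic carbon was removed and the number moved by a 1.2-fold lower number from compound 1 to compound 2 (0.09 log units; within the scatter). Compound 3, which carries a different aryl group on its chain, gives a value close to compound 2 as well. Removing two methoxy groups from the aryl on the chain is therefore expected to give a 1.1-fold higher number from compound 2 to compound 4 (0.04 log units; within the scatter). For compound 4 the estimate in this assay is 16000 nM, between 7000 nM and 36000 nM.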

Compound 4, half-maximal inhibitory concentration: 14900 nM
Compound 4: middle estimate off by 1.1-fold (0.03 log units), on the high side; the range from low to high includes it.
By their numbers in this assay, from the lowest: compounds 2, 4, 3 and 1 (each within the scatter of the next).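

Replacing the 3,4,5-trimethoxyphenyl on the chain with 4-methoxyphenyl gives a 1.0-fold higher number from compound 2 to compound 4 (0.01 log units; within the scatter) in this assay, and this is the first step shown at this place, as the earlier step removed a methoxy on an aromatic carbon elsewhere in the molecule. Even with the group going from 12 heavy atoms to 8 and from 3 hydrogen-bond acceptors to 1, the two numbers cannot be told apart, so this assay does not distinguish compounds with and without those two extra methoxy groups at this place. Nothing available explains why these two compounds read alike.

Going by these compounds, it remains open whether any group at this place can move the number beyond the scatter, such as a phenyl without methoxy or an aryl carrying an amine or a carboxylic acid. Whether compound 2 and compound 4 also read alike in other cells or at other times is open too.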